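This account rests on a few compounds, and the source may have more. Where it says the series, first, only, none or still open, it means among the compounds named here.

Measured so far in an assay on cells for displacement of a labelled ligand from Glucagon receptor (Homo sapiens), in the presence of a further agent that is not named here; on this read-out higher numbers stand for weaker inhibition and lower numbers for stronger inhibition:
Compound 1 `CCCC(Oc1ccc(-n2cc(F)cn2)cc1)c1ccc(C(=O)NCCC(=O)O)cc1` gives 1700 nM.
Compound 2 `CCCC(Oc1ccc(-n2cc(C(=O)N(C)C)cn2)cc1)c1ccc(C(=O)NCCC(=O)O)cc1` gives 6500 nM.
Compound 3 `CCCC(Oc1ccc(-n2cccn2)cc1)c1ccc(C(=O)NCCC(=O)O)cc1` gives 4100 nM.

Compound 3 stands second highest of the three numbers: compound 2 is within the scatter of it, while compound 1 is lower, a 2.4-fold higher number from compound 1 to compound 3 (0.38 log units; beyond the scatter) read in reverse. Compound 4 `CCCC(Oc1ccc(-n2cc(C(F)(F)F)c(C)n2)cc1)c1ccc(C(=O)NCCC(=O)O)cc1` differs from compound 3 by 3-methyl-4-(trifluoromethyl)-1H-pyrazol-1-yl in place of 1H-pyrazol-1-yl on an aromatic carbon. Among the measured compounds shown here, two steps bear on this: a 2.4-fold higher number from compound 1 to compound 3 (0.38 log units; beyond the scatter) shows that a fluoro on the same ring gave a lower number than the bare ring, whereas a 1.6-fold lower number from compound 2 to compound 3 (0.20 log units; within the scatter) shows a dimethylcarbamoyl there gave no change beyond the scatter. Groups on this ring thus move this assay in either direction by modest amounts. He therefore expects a small step toward a lower number, a 2.1-fold lower number from compound 3 to compound 4 (0.31 log units; beyond the scatter), with compound 4 estimated at 2000 nM, between 600 nM and 6000 nM.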

Compound 4, inhibition constant: 1100 nM
For compound 4 the middle estimate is 1.8-fold (0.26 log units) above the measured one; the range from low to high includes it.
By their numbers in this assay, from the lowest: compounds 4 and 1 (each within the scatter of the next); then compounds 3 and 2 (each within the scatter of the next).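

In this assay, a pyrazole ring carrying two groups at once is accepted at this aromatic carbon, para to a large group, and the change lowers the number (a 3.7-fold lower number from compound 3 to compound 4 (0.57 log units; beyond the scatter)). The gap is wider against the dimethylcarbamoyl analogue (a 5.9-fold lower number from compound 2 to compound 4 (0.77 log units; beyond the scatter)), yet the step from the single fluoro (a 1.5-fold lower number from compound 1 to compound 4 (0.19 log units; within the scatter)) shows no gain over 4-fluoro-1H-pyrazol-1-yl. Nothing measured here accounts for these differences.

The compounds shown leave open whether the methyl or the trifluoromethyl carries the step from the bare ring. They also leave open how an amine or a carboxylic acid on that ring would read.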